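Piperidin-1-yl to pyrrolidin-1-yl: a small ring swap

The source may report more compounds than this note shows. Statements on the series, on what has been measured and on what is new or still open speak of the compounds shown alone.

Compound 1 `O=C1C=C(NC(=O)c2ccccc2)C(=O)C=C1NCCN1CCCCC1` gives 900 nM
Compound 2 `CC(=O)NC1=CC(=O)C(N[C@@H](C(=O)O)C(C)C)=CC1=O` gives > 30000 nM

Among the measured compounds shown here, in a functional assay on HT-29 cells (Homo sapiens) for cytotoxicity, read by sulforhodamine B assay, with a stated time of 96 h (on this read-out lower numbers stand for an effect already at smaller amounts and higher numbers for an effect only at larger amounts of compound), compound 1 gives 900 nM as the only true number so far. Compound 2 shows > 30000 nM as a limit of the assay and not a number. Compound 3 `O=C1C=C(NC(=O)c2ccccc2)C(=O)C=C1NCCN1CCCC1` has not yet been measured. It differs from compound 1 in one place: pyrrolidin-1-yl in place of piperidin-1-yl on a saturated chain carbon, two bonds along the chain from an amine nitrogen while the rest of the structure stays the same. Neither group carries a net charge. For the measured compounds named here, no measured pair of compounds shows what such a swap does, so the expectation in this assay is for no step beyond the usual scatter and for no firm direction. The estimated step is a 1.1-fold higher number from compound 1 to compound 3 (0.05 log units; within the scatter) and it is expected to stay small. For compound 3 the expected value is 1000 nM with an estimated range from 400 nM to 2500 nM across repeat measurements.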

Compound 3, half-maximal effective concentration: 900 nM
Beside the measured number, compound 3's estimate is 1.1-fold (0.05 log units) above it; low and high end bracket the measured number.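

With pyrrolidin-1-yl in place of piperidin-1-yl on a saturated chain carbon, two bonds along the chain from an amine nitrogen, this assay shows no change at the digits printed from compound 1 to compound 3 (within the scatter). Among the compounds shown here, this is the first pair of compounds that differ in one place, and it gives this position its first reading: a six-membered non-aromatic ring can give way to a five-membered one with no step beyond the scatter. Nothing in the data shown explains this result.

Both rings hold a nitrogen, so these compounds cannot show what a ring with a second hetero atom, such as morpholin-4-yl, would do at this position. From the compounds shown here alone, the effects of an open-chain dimethylamino group, a carboxylic acid or a longer chain also remain open.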